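Benzofuran for Furan on Two Related Nucleoside Cores

The source may hold more compounds than are shown below. What is called first, only, known or untested is meant among the compounds shown, and "the series" means these compounds.

Of the compounds shown here, three have so far been tested in a functional assay on HeLa S3 cells (Homo sapiens) for antiproliferative activity, read by XTT assay, with a stated time of 72 h; on this read-out lower numbers stand for stronger inhibition and higher numbers for weaker inhibition. Compound 1, `O=c1[nH]cnc2c1c(-c1ccoc1)cn2[C@@H]1O[C@H](CO)[C@@H](O)[C@H]1O`, gives in this assay only a limit, > 20000 nM. Compound 3, `O=c1[nH]cnc2c1c(-c1cc3ccccc3o1)cn2[C@@H]1O[C@H](CO)[C@@H](O)[C@H]1O`, gives in this assay likewise only a limit, > 20000 nM. Compound 3 arises from compound 1 by a single change, (1-benzofuran-2-yl in place of furan-3-yl on an aromatic carbon), and the step this change made, a step that the two limits leave unreadable from compound 1 to compound 3, cannot be read in size, as both ends are limits rather than numbers. Compound 2, `Cc1nc(N)c2c(-c3ccoc3)cn([C@@H]3O[C@H](CO)[C@@H](O)[C@H]3O)c2n1`, is built on a different core; the difference between the two cores is not broken down here. In this assay compound 2 also gives only a limit, > 20000 nM.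

Compound 4, `Cc1nc(N)c2c(-c3cc4ccccc4o3)cn([C@@H]3O[C@H](CO)[C@@H](O)[C@H]3O)c2n1`, is still to be measured. It differs from compound 2 by 1-benzofuran-2-yl in place of furan-3-yl on an aromatic carbon, which is the same change that leads from compound 1 to compound 3, the two places being described in the same words. Among the compounds with values here, all of the values gathered so far share one feature, (the limit of > 20000 nM in this assay, at which 3 of the 3 values shown sit), so no measured step gives a direction for the change. The step expected in this assay is a step that the limit leaves unreadable from compound 2 to compound 4, an estimate that rests on the limit of > 20000 nM in this assay, at which 3 of the 3 values shown sit, and on the unreadable step that the two limits leave unreadable from compound 1 to compound 3. Compound 4 is therefore expected to give about 30000 nM, estimated to fall between 8000 nM and 100000 nM, and most probably only a limit again.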

Compound 4, half-maximal inhibitory concentration: > 20000 nM
Compound 4 gave a limit, no number (the forecaster's own chance of this, stated with the estimate: 85%); the middle value lies beyond the limit too.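

In this assay compound 4 gives > 20000 nM as well, which is only a limit. The step from compound 2 to compound 4 therefore has a limit at both ends, and its size cannot be read. All the results share one feature: the limit of > 20000 nM in this assay, at which 4 of the 4 values shown sit.

From the compounds shown here alone, whether 1-benzofuran-2-yl in place of furan-3-yl changes antiproliferative activity at all, on either core, stays open.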